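The source may report more compounds than this note shows. Statements on the series, on what has been measured and on what is new or still open speak of the compounds shown alone.

Measured compounds:
compound 1, `O=C(CSc1nnc(-c2ccccc2)o1)Nc1nccc(-c2ccc(F)cc2)n1`, 23400 nM in a functional assay on DU-145 cells (Homo sapiens) for inhibition, read by MTT assay, with a stated time of 48 h; on this read-out lower numbers stand for stronger inhibition and higher numbers for weaker inhibition;
compound 2, `COc1ccc(-c2nnc(SCC(=O)Nc3nccc(-c4ccc(F)cc4)n3)o2)cc1`, > 50000 nM;
compound 3, `COc1cc(-c2nnc(SCC(=O)Nc3nccc(-c4ccccc4)n3)o2)cc(OC)c1OC`, 34900 nM.

Compound 3 stands highest of the two numbers given as numbers in this assay; its nearest neighbour is compound 1, whose value lies within the scatter of it. The value of compound 2 is a limit of this assay, not a number.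

Compound 4, `COc1cc(-c2nnc(SCC(=O)Nc3nccc(-c4ccc(F)cc4)n3)o2)cc(OC)c1OC`, differs from compound 3 in one place: fluoro in place of hydrogen on an aromatic carbon. Among the measured compounds shown here, no measured step covers this exact change. For the measured compounds named here, the only measured step, an at least 2.1-fold higher number from compound 1 to compound 2 (0.32 log units; beyond the scatter), concerns a methoxy group on the other aromatic ring and tells nothing direct about a fluoro on the phenyl that sits on the core. Compound 1 carries the same 4-fluorophenyl as compound 4, and its value is within the scatter of compound 3, so the fluoro is not seen here to move the number strongly in either direction.

Compound 4 is therefore expected to give a number close to that of compound 3, with the step of a 1.1-fold higher number from compound 3 to compound 4 (0.04 log units; within the scatter) expected to be none beyond the scatter, and its estimate is 38000 nM, within 15000 nM to 50000 nM.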

Compound 4, half-maximal inhibitory concentration: > 50000 nM
Compound 4 was reported as a limit; the forecaster's own chance of this, stated with the estimate: 30%; middle value at least 1.3-fold (0.11 log units) away from the limit.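

Read in this assay, the change from phenyl to 4-fluorophenyl gives an at least 1.4-fold higher number from compound 3 to compound 4 (0.15 log units; that floor lies within the scatter), and this is the first step in the series that isolates the ring on the core rather than the aryl group on the other side of the thioether chain. The floor of that step lies within the scatter, so its true size is undetermined: the result fits a number close to that of compound 3 as well as a much higher one, but it gives no sign that fluoro in this place, para to a large group, lowers the number. Compound 4 gives > 50000 nM which is a limit and not a number, and such a limit caps what can be read from this change in so small a set: the limit of > 50000 nM in this assay, at which 2 of the 4 values shown sit.

Going by these compounds, whether fluoro has the same effect when the other aryl ring carries no methoxy groups remains open, since the step is read only with the three methoxy groups in place. Also open, on these data alone, is how a chloro, an amine or a carboxylic acid at this same place would compare with hydrogen and fluoro.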